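The source may hold more compounds than are shown below. What is called first, only, known or untested is meant among the compounds shown, and "the series" means these compounds.

In a functional assay on BT-20 cells (Homo sapiens) for antiproliferative activity, read by trypan blue exclusion (on this read-out lower numbers stand for stronger inhibition and higher numbers for weaker inhibition), three compounds have been measured so far:

Compound 1 `COc1ccc(/C=C/S(=O)(=O)Cc2ccc(OC)cc2)cc1` reaches only the assay's limit of > 20000 nM.
Compound 2 `COc1ccc(CS(=O)(=O)/C=C/c2ccc(F)cc2)cc1` gives 1500 nM.
Compound 3 `COc1ccc(CS(=O)(=O)/C=C/c2ccc(N)cc2)cc1` likewise sits at the assay's limit of > 20000 nM.

For the measured compounds named here, compound 2 therefore holds the only number among the three, the two other results being limits (the limit of > 20000 nM in this assay, at which 2 of the 3 values shown sit). Fluoro in place of methoxy brought an at least 13-fold lower number from compound 1 to compound 2 (1.12 log units; beyond the scatter), and amino in place of fluoro brought an at least 13-fold higher number from compound 2 to compound 3 (1.12 log units; beyond the scatter). Compound 4 `COc1ccc(CS(=O)(=O)/C=C/c2ccc(F)cc2Cl)cc1` differs from compound 2 by chloro in place of hydrogen on an aromatic carbon. Going by the values given here, no measured step covers an added chloro; the known steps show only that exchanging the group on the aromatic carbon moves the result strongly. For compound 4 the expected step is a 1.5-fold lower number from compound 2 to compound 4 (0.18 log units; within the scatter), within the scatter. Compound 4 is thus estimated at 1000 nM, between 300 nM and 5000 nM.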

Compound 4, half-maximal inhibitory concentration: 2500 nM
For compound 4 the middle estimate is 2.5-fold (0.40 log units) below the measured one; the measured number falls inside the stated range.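

In this assay, chloro in place of hydrogen, ortho to a large group and meta to a fluoro group, gave a 1.7-fold higher number from compound 2 to compound 4 (0.22 log units; within the scatter) and so stayed within the usual scatter. The earlier exchanges of one group for another on an aromatic carbon had each moved the result beyond the scatter, whereas this added chloro leaves a measured number rather than a limit. Nothing shown here bears on the reason for this result.

From the compounds shown here alone, whether methyl, methoxy or an amine at this position would also stay within the scatter remains open. So does the effect of chloro on the other carbons of that ring.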